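From 2-fluorophenyl to 3-fluorophenyl on the shared core

The source may report more compounds than this note shows. Statements on the series, on what has been measured and on what is new or still open speak of the compounds shown alone.

Going by the values given here, in a functional assay on cells (Neutrophil, Homo sapiens) for inhibition, with a stated time of 10 min (on this read-out higher numbers stand for weaker inhibition and lower numbers for stronger inhibition), compound 3 (`CCOC(=O)c1cnn2c1N(C(=O)Nc1ccccc1F)C(c1ccccc1)C2`) gives 7.5 nM, the only actual number so far. Compound 2 (`CCOC(=O)c1cnn2c1N(C(=O)Nc1ccccc1)C(c1ccccc1)C2`) reads > 1000 nM, which is a limit of the assay. Compound 1 (`O=C(Nc1cccc(F)c1)N1c2ccnn2CC1c1ccccc1`), which carries 3-fluorophenyl on a different core, reads > 1000 nM, also a limit of the assay. The remaining values therefore sit at the limit of > 1000 nM in this assay, at which 2 of the 3 values shown sit.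

Compound 4 (`CCOC(=O)c1cnn2c1N(C(=O)Nc1cccc(F)c1)C(c1ccccc1)C2`) differs from compound 3 as follows: 3-fluorophenyl in place of 2-fluorophenyl on an amide-type nitrogen. In words, this is 3-fluorophenyl in place of 2-fluorophenyl on an amide-type nitrogen.

Among the compounds with values here, the only measured step that bears on this change is an at least 130-fold lower number from compound 2 to compound 3 (2.12 log units; beyond the scatter), a large step with fluoro in place of hydrogen on an aromatic carbon. Within the data shown here, no measured step moves the fluorine, but the change gives up the 2-fluorophenyl group of compound 3, so part of that gain is expected to be lost. The expected step is a 27-fold higher number from compound 3 to compound 4 (1.43 log units; beyond the scatter), towards a higher number in this assay. For compound 4 the estimated value is 200 nM, with an expected range of 15 nM to 2000 nM.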

Compound 4, half-maximal inhibitory concentration: 111 nM
Compound 4: the middle estimate sits 1.8-fold (0.26 log units) above what was measured; low and high end bracket the measured number.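

In this assay, the placing of the fluorine counts and not only its presence, with a 15-fold higher number from compound 3 to compound 4 (1.17 log units; beyond the scatter) for 3-fluorophenyl in place of 2-fluorophenyl on the amide-type nitrogen. 3-fluorophenyl still keeps part of the gain over plain phenyl, with an at least 9.0-fold lower number from compound 2 to compound 4 (0.95 log units; beyond the scatter), and the ethoxycarbonyl group now shows its own contribution with 3-fluorophenyl held fixed, with an at least 9.0-fold lower number from compound 1 to compound 4 (0.95 log units; beyond the scatter). Both of these steps start from a limit of the assay and not from a number: the limit of > 1000 nM in this assay, at which 2 of the 4 values shown sit.

Open, as far as these compounds go, is whether a 2-chlorophenyl or 2-methoxyphenyl group on the amide-type nitrogen would match the 2-fluorophenyl group of compound 3. Also open, from the compounds shown here alone, is whether a carboxylic acid or a primary amide could stand in for the ethoxycarbonyl group on the shared core.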